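The source may report more compounds than this note shows. Statements on the series, on what has been measured and on what is new or still open speak of the compounds shown alone.

Measured in an assay on isolated protein for inhibition of G protein-coupled receptor kinase 6 (Homo sapiens), read by scintillation counting, radiometric assay and 33P incorporation, with a stated time of 80 min, in the presence of a further agent that is not named here; a higher number here means a weaker inhibitor, a lower number a stronger inhibitor:

compound 1, `CCc1cc(Nc2nc(N[C@@H](C)c3ccc(F)cc3)nc3cc(F)ccc23)n[nH]1`, gives 100 nM
compound 2, `CCc1cc(Nc2nc(N[C@@H](C)c3ccc(F)cc3)nc3ccccc23)n[nH]1`, gives 120 nM
compound 3, `CCc1cc(Nc2nc(N[C@@H](C)c3ccc(F)cc3)nc3cc(Cl)ccc23)n[nH]1`, gives 440 nM

Compound 2 stands second highest of the three numbers. It sits within the scatter of compound 1, the step being a 1.2-fold higher number from compound 1 to compound 2 (0.08 log units; within the scatter), while compound 3 lies further off, with a 3.7-fold higher number from compound 2 to compound 3 (0.56 log units; beyond the scatter). The third measured step, a 4.4-fold higher number from compound 1 to compound 3 (0.64 log units; beyond the scatter), is of similar modest size. All three steps change only the substituent on an aromatic carbon of the shared core.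

Compound 4, `CCc1cc(Nc2nc(N[C@@H](C)C3CCCCC3)nc3ccccc23)n[nH]1`, differs from compound 2 in another place: cyclohexyl in place of 4-fluorophenyl on a saturated chain carbon bound to a nitrogen on an aromatic ring and a saturated chain carbon. Among the measured compounds shown here, none of the measured steps touches that chain carbon, so none bears directly on this change, and the direction of the step in this assay cannot be read from the measured compounds; the expectation must therefore be set wide. Compound 4 is estimated at 350 nM, with a range from 80 nM to 2000 nM. This estimate means an expected step of a 2.9-fold higher number from compound 2 to compound 4 (0.46 log units; beyond the scatter), a number the measurement will settle.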

Compound 4, half-maximal inhibitory concentration: 960 nM
Estimate against measurement, compound 4: 2.7-fold (0.44 log units) below; low and high end bracket the measured number.
By their numbers in this assay, from the lowest: compounds 1 and 2 (each within the scatter of the next); then compound 3; then compound 4.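

In this assay, among the compounds shown here, the change on this saturated chain carbon gives an 8.0-fold higher number from compound 2 to compound 4 (0.90 log units; beyond the scatter) and so shows that this place, which no earlier step touched, responds to the group it carries. The earlier steps shown here all lay on an aromatic carbon of the shared core and said nothing about this part of the molecule. Cyclohexyl and 4-fluorophenyl are both six-membered rings of carbon with no hydrogen-bond donors or acceptors, yet here the non-aromatic ring gives the weaker inhibitor of the pair, and nothing at hand explains the difference.

The compounds shown leave open whether a plain phenyl, without the fluoro, or a piperidine ring would stand nearer compound 2 or compound 4. They also leave open whether the same change would give a step of like size on the core of compound 1.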